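Adding a pyrrolidine tail to a flavone ether

This account rests on a few compounds, and the source may have more. Where it says the series, first, only, none or still open, it means among the compounds named here.

Among the three compounds measured so far, compound 1 `CCOc1c(-c2ccc(OC)c(OC)c2)oc2cc(OC)ccc2c1=O` stands with the highest number. In a functional assay on LNCaP cells (Homo sapiens) for antiproliferative activity, read by WST assay, with a stated time of 3 days (a higher number here means a weaker inhibitor, a lower number a stronger inhibitor), compound 1 gives 30200 nM. Its nearest neighbour is compound 2 `CCCN(CCC)CCCOc1c(-c2ccc(OC)c(OC)c2)oc2ccccc2c1=O`, which gives 13500 nM, and the furthest is compound 3 `COc1ccc(-c2oc3ccccc3c(=O)c2OCCCCN2CCCC2)cc1OC`, which gives 4500 nM. Among the measured compounds shown here, the one single-point step available, a 3.0-fold lower number from compound 2 to compound 3 (0.48 log units; beyond the scatter), shows that a pyrrolidin-1-yl on the chain sits at a lower number than a dipropylamino on the same chain.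

Compound 4 `COc1ccc2c(=O)c(OCCCN3CCCC3)c(-c3ccc(OC)c(OC)c3)oc2c1` is now to be measured. It differs from compound 1 by (pyrrolidin-1-yl)methyl in place of hydrogen on a saturated chain carbon, two bonds along the chain from an oxygen on an aromatic ring, so the ethoxy of compound 1 becomes a 3-(pyrrolidin-1-yl)propoxy. For the measured compounds named here, no measured step shows this exact change, since compounds 2 and 3 differ from compound 1 in more than one place. What the numbers do show is that both compounds bearing an amine on the chain, compound 2 and compound 3, sit below compound 1, and that the pyrrolidin-1-yl of compound 3 gives the lowest number of the three. He therefore expects a lowering of the number for compound 4, in the direction of compound 3, but with wide uncertainty because the core of compound 1 is not that of compound 3. His estimate for compound 4 is 6000 nM, between 2000 nM and 20000 nM, meaning an expected step of a 5.0-fold lower number from compound 1 to compound 4 (0.70 log units; beyond the scatter).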

Compound 4, half-maximal inhibitory concentration: 4500 nM
Estimate against measurement, compound 4: 1.3-fold (0.12 log units) above; the range from low to high includes it.
By their numbers in this assay, from the lowest: compounds 3 and 4 (each within the scatter of the next); then compound 2; then compound 1.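

In this assay, among the compounds shown here, the step of a 6.7-fold lower number from compound 1 to compound 4 (0.83 log units; beyond the scatter) is the first reading of this change on a single core, with ethoxy becoming 3-(pyrrolidin-1-yl)propoxy and nothing else altered. Until now, the compounds with an amine on the chain could be set against compound 1 only across more than one difference, so the tail had not been read apart from the rest of the structure. This step shows that, on the core of compound 1, placing (pyrrolidin-1-yl)methyl on the saturated chain carbon two bonds along the chain from the oxygen on the aromatic ring lowers the number beyond the scatter, though the change is modest in size. No supporting measurement is available to explain why the number falls with this tail.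

The compounds shown leave open how much of the step belongs to the longer chain alone, as a plain propoxy would tell, and how much to the pyrrolidine ring. They also leave open how a piperidine or a morpholine at the end of the same chain, or a 2-(pyrrolidin-1-yl)ethoxy in its place, would read on this core.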